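The compounds below may be only part of what the source reports. "The series", "measured", "known", "first", "only" and "open" are said of these compounds alone.

Of the compounds shown here, three sharing one core have been measured in a functional assay on SF-268 cells (Homo sapiens) for inhibition, read by sulforhodamine B assay, with a stated time of 48 h, tested at 10 uM; a lower number here means less inhibition, a higher number more inhibition at the concentration tested (going by the name of the read-out). Compound 1 `c1ccc(-c2cn3ccnc3c(-c3ccc4ncn(C5CCCCC5)c4c3)n2)cc1` carries an unsubstituted phenyl and gives 21.7%. Compound 2 `COc1ccc(-c2cn3ccnc3c(-c3ccc4ncn(C5CCCCC5)c4c3)n2)cc1` bears a 4-methoxyphenyl and gives 49.9%, while compound 3 `COc1ccccc1-c1cn2ccnc2c(-c2ccc3ncn(C4CCCCC4)c3c2)n1` bears a 2-methoxyphenyl and gives 8.04%. Compound 3 thus stands lowest of the three, with compound 1 nearest and compound 2 furthest away. The steps show that the substituent on this phenyl matters: a number 28.2 percentage points higher from compound 1 to compound 2 (beyond the scatter), whereas a number 13.7 percentage points lower from compound 1 to compound 3 (beyond the scatter), and a number 41.9 percentage points lower from compound 2 to compound 3 (beyond the scatter).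

Compound 4 `FC(F)(F)c1cccc(-c2cn3ccnc3c(-c3ccc4ncn(C5CCCCC5)c4c3)n2)c1` replaces the group in one place: 3-(trifluoromethyl)phenyl in place of 2-methoxyphenyl on an aromatic carbon. Going by the values given here, no measured step covers a trifluoromethyl group, so the 2-methoxy to 4-methoxy and hydrogen steps are only indirect guides; they suggest that moving away from the 2-methoxyphenyl tends to raise inhibition in this assay, though by an uncertain amount. Compound 4 is therefore expected to lie near the unsubstituted compound 1, at about 25%, within a wide range from 5% to 55%. This estimate means a step of a number 17 percentage points higher from compound 3 to compound 4 (beyond the scatter), expected but far from certain.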

Compound 4, a percentage reported as inhibition, at one concentration (the size of the read-out at that concentration, not a potency): 3.3%
The estimate for compound 4 lay 21.7 percentage points above the measured number, outside the stated range (below it).
By their numbers in this assay, from the lowest: compounds 4 and 3 (each within the scatter of the next); then compound 1; then compound 2.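

In this assay, the 3-(trifluoromethyl)phenyl and the 2-methoxyphenyl cannot be told apart, with a number 4.7 percentage points lower from compound 3 to compound 4 (within the scatter) in the data. A second group on this phenyl therefore joins the 2-methoxy in giving less inhibition than the unsubstituted phenyl, with a number 18.4 percentage points lower from compound 1 to compound 4 (beyond the scatter) as the step, and the new group also stands well short of the 4-methoxyphenyl, with a number 46.6 percentage points lower from compound 2 to compound 4 (beyond the scatter) as the step. Of the three substituted compounds, only compound 2 lies above compound 1, and no measurement at hand explains this difference.

As far as these compounds go, it remains open whether the higher number of compound 2 is specific to methoxy, which an amine or a hydroxyl on the phenyl could test. The effect of placement also stays unsettled, since methoxy and trifluoromethyl have not been compared at the same ring position here.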